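Isopropoxy for pyridin-2-yl: expected solubility of compound 4

The source may report more compounds than this note shows. Statements on the series, on what has been measured and on what is new or still open speak of the compounds shown alone.

Compound 1 `Cc1cc(C(=O)NNS(=O)(=O)c2ccccc2F)cc(-c2ccccn2)c1`: 12.5 ug/mL
Compound 2 `C=CCOc1ccc(F)c(C(=O)NNS(=O)(=O)c2ccccc2)c1`: 50 ug/mL
Compound 3 `O=C(NNS(=O)(=O)c1ccccc1F)c1cccc(-n2cccn2)c1`: 50 ug/mL

In a physicochemical assay for solubility, read by nephelometry, in phosphate buffer, measured as kinetic solubility, at pH 6.5 (on this read-out higher numbers stand for higher solubility and lower numbers for lower solubility), compound 1 gives the lowest of the three numbers; compound 2 and compound 3 both lie higher by a margin beyond the usual scatter. Compound 4 `Cc1cc(OC(C)C)cc(C(=O)NNS(=O)(=O)c2ccccc2F)c1` has not yet been measured. It differs from compound 1 in one place: isopropoxy in place of pyridin-2-yl on an aromatic carbon. Going by the values given here, no measured pair separates these two groups from each other, so the direction rests on expectation alone. A step that is modest and upward is expected, a 2.0-fold higher number from compound 1 to compound 4 (0.30 log units; within the scatter), but a result within the scatter of compound 1 would not surprise. For compound 4 the estimated value is 25 ug/mL, with a range from 8 ug/mL to 70 ug/mL.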

Compound 4, solubility: 12.5 ug/mL
Compound 4: the middle estimate sits 2.0-fold (0.30 log units) above what was measured; the measured number falls inside the stated range.
By their numbers in this assay, from the lowest: compounds 1 and 4 (each within the scatter of the next); then compounds 2 and 3 (each within the scatter of the next).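

In this assay, going by these compounds alone, putting isopropoxy in place of pyridin-2-yl on this aromatic carbon gives no change at the digits printed from compound 1 to compound 4 (within the scatter), the first comparison at this position. A six-membered aromatic ring and a smaller open group with no ring thus read alike here. Nothing at hand accounts for this result.

From the compounds shown here alone, whether an amine or a carboxylic acid on this aromatic carbon would separate from compound 1 in this assay remains open. So does whether a longer chain in place of isopropoxy would still read like compound 4.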